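This account rests on a few compounds, and the source may have more. Where it says the series, first, only, none or still open, it means among the compounds named here.

Series on the shared core of compound 1 `COc1ccc(N)c(C2=NN(C(C)=O)CC2)c1`, varied only at the carbonyl carbon. In an assay on isolated protein for inhibition of Nitric oxide synthase, inducible (Homo sapiens), with a stated time of 30 min, tested at 1 mM (a higher number here means more inhibition at the concentration tested (going by the name of the read-out), a lower number less inhibition), compound 1 gives 20.4%. Compound 2 `CCCCC(=O)N1CCC(c2cc(OC)ccc2N)=N1` gives 0.18% and compound 3 `COc1ccc(N)c(C2=NN(C(=O)C3CCC3)CC2)c1` gives 1.91%; the step of a number 18.5 percentage points lower from compound 1 to compound 3 (beyond the scatter) lies beyond the scatter, while a number 1.7 percentage points higher from compound 2 to compound 3 (within the scatter) does not, so compound 3 stands second of the three numbers, close to compound 2 and well under compound 1. Compound 4 `COc1ccc(N)c(C2=NN(C(=O)C3CCCC3)CC2)c1` carries cyclopentyl in place of cyclobutyl on a carbonyl carbon. Within the data shown here, the steps that bear on it are a number 18.5 percentage points lower from compound 1 to compound 3 (beyond the scatter), modest, and a number 1.7 percentage points higher from compound 2 to compound 3 (within the scatter), negligible: once methyl is replaced, a larger group on the carbonyl carbon has made no further difference. No step beyond the scatter is therefore expected in this assay, a number 0.6 percentage points higher from compound 3 to compound 4 (within the scatter). Compound 4 is estimated at 2.5%, between 0% and 10%.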

Compound 4, a percentage reported as inhibition, at one concentration (the size of the read-out at that concentration, not a potency): 1.85%
Beside the measured number, compound 4's estimate is 0.7 percentage points above it, within the range that was stated.
By their numbers in this assay, from the lowest: compounds 2, 4 and 3 (each within the scatter of the next); then compound 1.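

In this assay the swap of cyclobutyl for cyclopentyl on the carbonyl carbon gives a number 0.1 percentage points lower from compound 3 to compound 4 (within the scatter), so the added ring carbon makes no readable difference. The ring also reads the same as the open butyl chain, with a number 1.7 percentage points higher from compound 2 to compound 4 (within the scatter), while a number 18.6 percentage points lower from compound 1 to compound 4 (beyond the scatter) shows that the drop on leaving methyl holds for butyl, cyclobutyl and cyclopentyl alike. No measured evidence accounts for this flat response. Still open, as far as these compounds go, is whether ethyl, or an amine or carboxylic acid carried on the carbonyl carbon, would stay near compound 1 at 20.4% or fall with the larger groups.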